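The source may report more compounds than this note shows. Statements on the series, on what has been measured and on what is new or still open speak of the compounds shown alone.

Measured in an ADME assay on microsomes from liver (Rattus norvegicus) for metabolic stability; on this read-out lower numbers stand for slow clearance and higher numbers for fast clearance:
- compound 1 `CNc1nc(NC2(C#N)CCCCC2)nc(-n2cccn2)n1`: 103 mL/min/kg
- compound 2 `CNc1nc(NC2(C#N)CCCCC2)nc(-n2ccnc2)n1`: 52 mL/min/kg
- compound 3 `CNc1nc(Cl)nc(NC2(C#N)CCCCC2)n1`: 867 mL/min/kg

Compound 3, at 867 mL/min/kg, has the highest number of the three, and both of the others lie clearly under it. The next structure, compound 4 `CNc1nc(C#N)nc(NC2(C#N)CCCCC2)n1`, carries cyano in place of chloro on an aromatic carbon.

Among the measured compounds shown here, two measured steps bear on this carbon. One is an 8.4-fold higher number from compound 1 to compound 3 (0.93 log units; beyond the scatter), where chloro replaces 1H-pyrazol-1-yl, and the other is a 17-fold higher number from compound 2 to compound 3 (1.22 log units; beyond the scatter), where chloro replaces 1H-imidazol-1-yl. The first is modest and the second large. In both, the compound with chloro has the higher number, so what sits at this place clearly matters for this assay.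

For the measured compounds named here, no measured compound carries cyano here, and cyano has no ring, unlike the two groups tested so far. The steps therefore give a direction more firmly than a size. A fall is expected, but a smaller one than either measured step. The expected change is a 2.6-fold lower number from compound 3 to compound 4 (0.42 log units; beyond the scatter), and this estimate is uncertain. For compound 4 the estimated value is 330 mL/min/kg, with an expected range from 120 mL/min/kg to 850 mL/min/kg.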

Compound 4, clearance: 122 mL/min/kg
For compound 4 the middle estimate is 2.7-fold (0.43 log units) above the measured one; measured number inside the range.
By their numbers in this assay, from the lowest: compounds 2, 1 and 4 (each within the scatter of the next, the first and the last beyond it); then compound 3.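

In this assay, the step of a 7.1-fold lower number from compound 3 to compound 4 (0.85 log units; beyond the scatter) shows that a group with no ring can also bring the number well down from that of the chloro compound, something the two ring-bearing groups alone could not show. Cyano cannot be told apart from 1H-pyrazol-1-yl, since a 1.2-fold higher number from compound 1 to compound 4 (0.07 log units; within the scatter) stays inside the usual scatter, whereas a 2.3-fold higher number from compound 2 to compound 4 (0.37 log units; beyond the scatter) is a modest step beyond the scatter that leaves 1H-imidazol-1-yl with the lower number. Among the four groups seen on this aromatic carbon, chloro is now the only one whose number lies beyond the scatter from all the others, so the sharp difference belongs to chloro rather than to the ring-bearing groups as a class.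

The data offer no measurement that explains why chloro stands apart in this way. Still open, on these data alone, is where a simple amine, a methoxy group or a longer alkyl chain on this carbon would fall, and whether changing the methylamino group would shift the number as much as changes at this carbon do.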